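The source may hold more compounds than are shown below. What is called first, only, known or untested is meant among the compounds shown, and "the series" means these compounds.

Measured in a functional assay on EC9706 cells (Homo sapiens) for cytotoxicity, read by MTT assay, with a stated time of 72 h; on this read-out higher numbers stand for weaker inhibition and lower numbers for stronger inhibition:
compound 1, `CCNC(=O)N1CCN(C(=S)SCc2cn(Cc3ccccc3F)nn2)CC1`: 23700 nM
compound 2, `NC(=O)N1CCN(C(=S)SCc2cn(Cc3ccc(Cl)cc3)nn2)CC1`: limit only

Compound 2 is known in this assay only as a limit of the assay, > 128000 nM, not as a number. Compound 2 thus sits at the limit of > 128000 nM in this assay, at which 1 of the 2 values shown sits. Compound 3, `CCNC(=O)N1CCN(C(=S)SCc2cn(Cc3ccc(Cl)cc3)nn2)CC1`, differs from compound 2 by ethyl in place of hydrogen on an amide-type nitrogen. Within the data shown here, no measured pair isolates this change. Compound 1, which carries the same ethylcarbamoyl group, gives 23700 nM in this assay, a number rather than a limit. A step toward stronger inhibition is expected from compound 2 to compound 3, of an at least 3.2-fold lower number from compound 2 to compound 3 (0.50 log units; beyond the scatter). Compound 3 is estimated at 40000 nM, within 12000 nM to 130000 nM.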

Compound 3, half-maximal inhibitory concentration: > 128000 nM
Compound 3: a limit, no number; the forecaster's own chance of this, stated with the estimate: 30%; middle value at least 3.2-fold (0.50 log units) away from the limit.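

In this assay, the ethylcarbamoyl group alone does not secure a number: compound 3 carries it and, like compound 2, stands only at a limit of the assay, so the step between them cannot be read. Between the two ethylcarbamoyl compounds, 4-chlorophenyl in place of 2-fluorophenyl on the saturated chain carbon gives an at least 5.4-fold higher number from compound 1 to compound 3 (0.73 log units; beyond the scatter). The limit is now shared: the limit of > 128000 nM in this assay, at which 2 of the 3 values shown sit.

As far as these compounds go, whether ethyl in place of hydrogen changes anything in the 2-fluorophenyl compounds stays open. Also open, from the compounds shown here alone, is whether a longer chain such as butyl on that amide-type nitrogen brings a number alongside 4-chlorophenyl.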